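A few compounds are considered here, and "the series" means these few. Any claim that something is new, unique, unknown or untested is made for them only; others in the source may bear on it.

Compound 1, `C=CC(=O)Nc1ccc(C(=O)Nc2ccc(C)c(Nc3nccc(-c4cccnc4)n3)c2)cc1`, carries a (vinylcarbonyl)amino group on an aromatic carbon, and in an ADME assay on BaF3 cells (Mus musculus) for cytotoxicity, read by CellTiter-Glo and CCK-8 assay, with a stated time of 72 h (on this read-out lower numbers stand for stronger inhibition of growth and higher numbers for weaker inhibition of growth), compound 1 gives 5600 nM. Compound 2, `CCC(=O)N(CCN(C)C)Cc1ccc(C(=O)Nc2ccc(C)c(Nc3nccc(-c4cccnc4)n3)c2)cc1`, replaces that group with a ((2-(dimethylamino)ethyl)(propanoyl)amino)methyl group, and in this assay compound 2 reaches only a limit of the assay, > 10000 nM. The change is recorded as an at least 1.7-fold higher number from compound 1 to compound 2 (0.25 log units; that floor lies within the scatter), so compound 2 stands at the limit of > 10000 nM in this assay, at which 1 of the 2 values shown sits, and its true value is not known, only its floor.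

Compound 3, `C=CC(=O)N(CCC(C)C)Cc1ccc(C(=O)Nc2ccc(C)c(Nc3nccc(-c4cccnc4)n3)c2)cc1`, is the next step: isopentyl(vinylcarbonyl)amino in place of (2-(dimethylamino)ethyl)(propanoyl)amino on a saturated chain carbon bound to an aromatic carbon. The vinylcarbonyl that compound 1 carried thus returns, though now on a methyl link and paired with an isopentyl chain rather than with the 2-(dimethylamino)ethyl chain. Among the measured compounds shown here, the only measured step that bears on this, an at least 1.7-fold higher number from compound 1 to compound 2 (0.25 log units; that floor lies within the scatter), was recorded as a floor and lies within the scatter, so it offers weak guidance. Because compound 1 sits at 5600 nM, compound 3 is expected to move toward that value, and the estimated step is an at least 1.6-fold lower number from compound 2 to compound 3 (0.22 log units; that floor lies within the scatter). Compound 3 is therefore estimated at 6000 nM in this assay, with a range from 2000 nM to 15000 nM.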

Compound 3, concentration for 50% growth inhibition: 5620 nM
For compound 3 the middle estimate is 1.1-fold (0.03 log units) above the measured one; the range from low to high includes it.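

Set on the same aromatic carbon, the (isopentyl(vinylcarbonyl)amino)methyl group of compound 3 and the (vinylcarbonyl)amino group of compound 1 cannot be told apart in this assay, with a 1.0-fold higher number from compound 1 to compound 3 (0.00 log units; within the scatter), which lies within the scatter. This shows that the vinylcarbonyl group can sit on a methyl link with an isopentyl chain on its nitrogen and still give a value within the scatter of compound 1, which the earlier pair could not show. The other new step, an at least 1.7-fold lower number from compound 2 to compound 3 (0.25 log units; that floor lies within the scatter), is only a floor, and it also lies within the scatter, so it gives no measured size for replacing (2-(dimethylamino)ethyl)(propanoyl)amino with isopentyl(vinylcarbonyl)amino, because compound 2 is recorded only as a limit of the assay: the limit of > 10000 nM in this assay, at which 1 of the 3 values shown sits.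

That replacement exchanges propanoyl for vinylcarbonyl and the 2-(dimethylamino)ethyl chain for isopentyl together, so the compounds shown do not separate the two changes. Also open, from the compounds shown here alone, is how a vinylcarbonyl group paired with the 2-(dimethylamino)ethyl chain, or with a shorter chain such as ethyl, would read here.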